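Methoxy for nitro at the limit of the series

A few compounds are considered here, and "the series" means these few. Any claim that something is new, unique, unknown or untested is made for them only; others in the source may bear on it.

Measured in a functional assay on A549 cells (Homo sapiens) for antiproliferative activity, read by MTT assay, with a stated time of 72 h (a higher number here means a weaker inhibitor, a lower number a stronger inhibitor), so far:
- compound 1 `CCOC(=O)C1=C(C)N=C(S)NC1c1cccc([N+](=O)[O-])c1` gives 44900 nM as a number
- compound 2 `CCOC(=O)C1=C(C)NC(=S)NC1c1ccc(O)c([N+](=O)[O-])c1` gives > 100000 nM as a limit

Compound 2 stands at the end of the measurable range: its reading (> 100000 nM) is a limit and not a number. Compound 3 `CCOC(=O)C1=C(C)NC(=S)NC1c1ccc(O)c(OC)c1` carries methoxy in place of nitro on an aromatic carbon in that same setting, ortho to a hydroxy group. Within the data shown here, no measured step covers this change, so only a modest move toward stronger inhibition in this assay is expected, and a second reading at the limit remains possible. The expected move runs an at least 1.5-fold lower number from compound 2 to compound 3 (0.18 log units; that floor lies within the scatter) as an estimate only. Compound 3 is estimated at 65000 nM within a range of 25000 nM to 100000 nM for now.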

Compound 3, half-maximal inhibitory concentration: > 100000 nM
Compound 3 was reported as a limit; the forecaster's own chance of this, stated with the estimate: 40%; middle value at least 1.5-fold (0.18 log units) from the limit.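

Among these compounds, compound 2 and compound 3 both give limits and not numbers, so no step between them can be read: the limit of > 100000 nM in this assay, at which 2 of the 3 values shown sit. The compounds shown leave open whether methoxy in place of nitro on an aromatic carbon changes antiproliferative activity at all.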